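This account rests on a few compounds, and the source may have more. Where it says the series, first, only, none or still open, it means among the compounds named here.

Among the measured compounds shown here, in a functional assay on HL-60 cells (Homo sapiens) for cytotoxicity, read by WST assay, with a stated time of 48 h (a higher number here means a weaker inhibitor, a lower number a stronger inhibitor), two compounds built on one shared core have numbers so far. Compound 1 `Oc1ccccc1/C=C/C[C@H]1C[C@@H]([C@@H](O)c2ccccc2)CO[C@@H]1c1ccccc1` gives 10800 nM, and compound 2 `Oc1cccc(/C=C/C[C@H]2C[C@@H]([C@@H](O)c3ccccc3)CO[C@@H]2c2ccccc2)c1` gives 12800 nM. These two values lie within the scatter of each other, so compound 2 cannot be separated from compound 1 on this evidence.

Compound 3 `O=[N+]([O-])c1ccc(/C=C/C[C@H]2C[C@@H]([C@@H](O)c3ccccc3)CO[C@@H]2c2ccccc2)cc1` keeps the shared core and differs from compound 2 in one place, on a double-bonded chain carbon bound to a double-bonded chain carbon, where 4-nitrophenyl stands in place of 3-hydroxyphenyl: 4-nitrophenyl in place of 3-hydroxyphenyl on a double-bonded chain carbon bound to a double-bonded chain carbon. For the measured compounds named here, only one measured step bears on this place, namely a 1.2-fold higher number from compound 1 to compound 2 (0.07 log units; within the scatter), with 3-hydroxyphenyl in place of 2-hydroxyphenyl. Going by the values given here, that step exchanged one hydroxyphenyl for another, and no measured compound carries 4-nitrophenyl, so the guidance is indirect. Among the compounds with values here, with only this small step to go on, no step beyond the scatter is expected in this assay, and neither direction is favoured. The expected change is a 1.2-fold lower number from compound 2 to compound 3 (0.07 log units; within the scatter). For compound 3 the estimate is 11000 nM, with an expected range from 4500 nM to 25000 nM.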

Compound 3, half-maximal inhibitory concentration: 4880 nM
Compound 3: middle estimate off by 2.3-fold (0.35 log units), on the high side; the range from low to high includes it.
By their numbers in this assay, from the lowest: compound 3; then compounds 1 and 2 (each within the scatter of the next).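

In this assay, the place on a double-bonded chain carbon bound to a double-bonded chain carbon turns out to be able to shift the number, which the exchange between the two hydroxyphenyl groups had not shown. With 4-nitrophenyl there is a 2.6-fold lower number from compound 2 to compound 3 (0.42 log units; beyond the scatter) and a 2.2-fold lower number from compound 1 to compound 3 (0.35 log units; beyond the scatter), so both steps are modest but lie beyond the scatter, and the group entering here differs from either hydroxyphenyl in more than the position of its substituent, carrying 0 hydrogen-bond donors and 2 hydrogen-bond acceptors. Nothing available accounts for these steps.

The compounds shown leave open whether the lower number goes with the nitro group itself or with the position it holds, as 4-nitrophenyl differs from 2-hydroxyphenyl and 3-hydroxyphenyl in both respects at once. On these data alone, it also remains open how an unsubstituted phenyl, a 4-hydroxyphenyl, a 4-aminophenyl or a 4-carboxyphenyl would stand at this place, and so whether the step from the hydroxyphenyl compounds is particular to 4-nitrophenyl.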